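Adding a Methoxy Group: Expected Cytotoxicity of Compound 4

The source may report more compounds than this note shows. Statements on the series, on what has been measured and on what is new or still open speak of the compounds shown alone.

Compound 1 `COC(=O)c1c(-c2ccc(O)cc2)oc2ccccc2c1=O` in a functional assay on Malme-3M cells (Homo sapiens) for cytotoxicity, read by MTT assay, with a stated time of 6 days (on this read-out higher numbers stand for an effect only at larger amounts of compound and lower numbers for an effect already at smaller amounts), gives > 25 ug/mL, which is a limit of the assay and not a number.
Compound 2 `COC(=O)c1c(-c2ccc(O)cc2)oc2ccc(OC)cc2c1=O` in this assay gives > 25 ug/mL, again a limit of the assay.
Compound 3 `O=C(O)c1c(-c2ccc([N+](=O)[O-])cc2)oc2ccccc2c1=O` in this assay gives > 25 ug/mL, also a limit of the assay.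

Compound 2 differs from compound 1 by methoxy in place of hydrogen on an aromatic carbon. The step that the two limits leave unreadable from compound 1 to compound 2 cannot be sized because the limit of > 25 ug/mL in this assay, at which 3 of the 3 values shown sit, covers both of its values. How the core of compound 3 differs from the core of compound 1 is not broken down here.

Compound 4 `COc1ccc2c(=O)c(C(=O)O)c(-c3ccc([N+](=O)[O-])cc3)oc2c1` is not yet measured; it differs from compound 3 by methoxy in place of hydrogen on an aromatic carbon, the same change, in the same place, as that from compound 1 to compound 2. The earlier step is unreadable, so the expected step that the limit leaves unreadable from compound 3 to compound 4 rests only on the limit at which all three measured compounds sit (the limit of > 25 ug/mL in this assay, at which 3 of the 3 values shown sit). Compound 4 is therefore expected to give about 30 ug/mL, most likely again reported only as a limit, with a plausible range estimated from 15 ug/mL to 100 ug/mL.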

Compound 4, concentration for half-maximal effect: > 25 ug/mL
Compound 4 gave a limit, no number (the forecaster's own chance of this, stated with the estimate: 75%); the middle value does not contradict the limit.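

Compound 3 and compound 4 both give a limit of the assay and not a number, so no step can be read between them: the limit of > 25 ug/mL in this assay, at which 4 of the 4 values shown sit. Going by these compounds, what stays open is whether methoxy in place of hydrogen on an aromatic carbon makes any difference in this assay, and what amount of any of these four compounds gives a half-maximal effect.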